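Fluoro in place of cyano on compound 3

The source may hold more compounds than are shown below. What is called first, only, known or untested is meant among the compounds shown, and "the series" means these compounds.

In a functional assay on DU-145 cells (Homo sapiens) for antiproliferative activity, read by sulforhodamine B assay, with a stated time of 48 h (on this read-out lower numbers stand for stronger inhibition of growth and higher numbers for weaker inhibition of growth), compound 1 `COc1ccc(N(C)c2nc(NC3CCCC3)c3ccccc3n2)cc1` gives 10200 nM as its reading. In this assay compound 3 `N#Cc1ccc(Nc2nc(NCCCO)c3ccccc3n2)cc1` gives 18700 nM and so stands within the usual scatter of compound 1. For compound 2 `N#Cc1ccc(Nc2nc(NC3CCCC3)c3ccccc3n2)cc1` the result is a limit and not a number (> 31300 nM).

Compound 4 `OCCCNc1nc(Nc2ccc(F)cc2)nc2ccccc12` has fluoro in place of cyano on an aromatic carbon, para to a large group fluoro in place of cyano on an aromatic carbon and keeps the 3-hydroxypropyl group of compound 3. Going by the values given here, the one measured step (an at least 1.6-fold lower number from compound 2 to compound 3 (0.22 log units; that floor lies within the scatter)) has a floor within the scatter. Among the compounds with values here, it also leaves the cyano group in place, so no measured step bears directly on this change.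

With nothing to set a direction, the expectation in this assay stays close to compound 3 (18700 nM). The expected step is small (a 1.2-fold lower number from compound 3 to compound 4 (0.07 log units; within the scatter)) and lies within the scatter. For compound 4 the estimated value is 16000 nM (expected range 7000 nM to 33000 nM).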

Compound 4, concentration for 50% growth inhibition: 20600 nM
The estimate for compound 4 lay 1.3-fold (0.11 log units) below the measured number; measured number inside the range.
By their numbers in this assay, from the lowest: compounds 1, 3 and 4 (each within the scatter of the next, the first and the last beyond it). At a limit, above all of these: compound 2.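

The step at this position now has a measured size: with the 3-hydroxypropyl group held in place, 4-cyanophenyl gives way to 4-fluorophenyl and this assay shows a 1.1-fold higher number from compound 3 to compound 4 (0.04 log units; within the scatter). Cyano leaves with its hydrogen-bond acceptor and triple bond, and fluoro enters with neither, yet the reading does not separate the two compounds. Going by these compounds alone, on this side chain, then, the two groups cannot be told apart in this growth read-out, which the earlier compounds, all of them carrying cyano or methoxy on that ring, could not show.

Compound 2 stands at a limit and not a number, so the same change cannot be read on the cyclopentyl side chain: the limit of > 31300 nM in this assay, at which 1 of the 4 values shown sits. From the compounds shown here alone, whether an amine or a carboxylic acid at this position, or a longer chain in place of the 3-hydroxypropyl group, would move the reading beyond the scatter stays open.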